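Adding a Second Chloro to the Core of Compound 1

A few compounds are considered here, and "the series" means these few. Any claim that something is new, unique, unknown or untested is made for them only; others in the source may bear on it.

The series is small, and its readings in an ADME assay on Vero cells (Chlorocebus sabaeus) for cytotoxicity, read by WST assay (a lower number here means that less compound is tolerated, a higher number that more compound is tolerated), are all limits rather than numbers. Compound 1 `O=c1[nH]c(Nc2cc(F)cc(F)c2)nc2cc(Cl)ccc12` gives >= 18000 nM, which is a limit of the assay. Compound 2 `O=c1[nH]c(Nc2cc(F)cc(F)c2)nc2cc(C(F)(F)F)ccc12` gives >= 7600 nM, again a limit. Compound 3 `Nc1ccc2c(=O)[nH]c(Nc3cc(F)cc(F)c3)nc2c1` gives > 25000 nM, also a limit. Because each value is a limit of > 25000 nM in this assay, at which 1 of the 3 values shown sits, the limit of >= 18000 nM in this assay, at which 1 of the 3 values shown sits (the limit of >= 7600 nM in this assay, at which 1 of the 3 values shown sits), none of the three compounds can be placed above or below another, and compound 1 stands only at its own limit.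

The steps among the measured compounds are unreadable for the same reason: a step that the two limits leave unreadable from compound 1 to compound 2, a step that the two limits leave unreadable from compound 1 to compound 3 and a step that the two limits leave unreadable from compound 2 to compound 3. None of them follows the change that leads to compound 4 `O=c1[nH]c(Nc2cc(F)cc(F)c2)nc2c(Cl)c(Cl)ccc12`, where chloro in place of hydrogen on an aromatic carbon on the shared core of compound 1. For the measured compounds named here, no measured step therefore speaks directly to it, and the only guidance is that compound 1 sits at a limit.

She expects compound 4 to be tolerated in this assay much as compound 1 is, with an estimated step of a number no higher from compound 1 to compound 4 (the limit leaves the size open), and she estimates 18000 nM with a range from 6000 nM to 50000 nM, most likely reported as a limit.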

Compound 4, half-maximal cytotoxic concentration: > 25000 nM
Compound 4 ended at the assay's limit; the forecaster's own chance of this, stated with the estimate: 75%; middle value at least 1.3-fold (0.14 log units) from the limit.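

In this assay compound 4 gives > 25000 nM, which is a limit of the assay. Compound 1 also stands only at a limit, so the step from compound 1 to compound 4 cannot be read. The compounds shown leave open whether the added chloro changes tolerance at all, and in which direction.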